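The source may hold more compounds than are shown below. What is called first, only, known or untested is meant among the compounds shown, and "the series" means these compounds.

Compound 1, `FC(F)(F)c1cccc(-c2nc3cnc(Nc4cnccn4)cc3[nH]2)c1`, gives 155000 nM in a physicochemical assay for solubility, using the shake flask method, measured as kinetic solubility, with a stated time of 20 h, at pH 2; a lower number here means a less soluble compound, a higher number a more soluble compound.
Compound 2, `Fc1cnc(Nc2cc3[nH]c(-c4cccc(C(F)(F)F)c4)nc3cn2)c(F)c1`, gives only a limit of the assay in this assay, < 5000 nM.

Compound 2 therefore stands at the floor of the measured numbers, and its value is one of the two shown, of which (the limit of < 5000 nM in this assay, at which 1 of the 2 values shown sits). Compound 3, `N#Cc1ccc(Nc2cc3[nH]c(-c4cccc(C(F)(F)F)c4)nc3cn2)nc1`, differs from compound 2 in one place: 5-cyanopyridin-2-yl in place of 3,5-difluoropyridin-2-yl on a nitrogen on an aromatic ring.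

Among the measured compounds shown here, only one measured step bears on this change. It is an at least 31-fold lower number from compound 1 to compound 2 (1.49 log units; beyond the scatter), a large drop when a six-membered ring with two ring nitrogens was exchanged for one with a single ring nitrogen carrying two fluorines. Compound 3 keeps a single ring nitrogen but adds a nitrile, which brings a second hydrogen-bond acceptor. The expected step in this assay is an at least 1.2-fold higher number from compound 2 to compound 3 (0.07 log units; that floor lies within the scatter), a small rise at most, with a fair chance that compound 3 also returns only a limit. Compound 3 is estimated at 6000 nM, within a range of 1500 nM to 30000 nM.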

Compound 3, solubility: < 5000 nM
Compound 3 gave a limit, no number; the forecaster's own chance of this, stated with the estimate: 50%; at least 1.2-fold (0.07 log units) between middle value and limit.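

A second group in place of pyrazin-2-yl on this nitrogen, 5-cyanopyridin-2-yl, brings in this assay an at least 31-fold lower number from compound 1 to compound 3 (1.49 log units; beyond the scatter), so the large drop does not depend on the two fluorines of the 3,5-difluoropyridin-2-yl group. The step from compound 2 to compound 3 cannot be read, as both values are limits of the assay and any difference between the two groups stays hidden. The values shown now gather at one end of the scale: the limit of < 5000 nM in this assay, at which 2 of the 3 values shown sit.

Open, going by these compounds, is how a pyridin-2-yl ring carrying an amine or a carboxylic acid, placed on this nitrogen, would read in this assay. Also open, on these data alone, is how far compound 2 and compound 3 lie beneath their shared limit.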